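A few compounds are considered here, and "the series" means these few. Any claim that something is new, unique, unknown or untested is made for them only; others in the source may bear on it.

Measured in a functional assay on CCRF-CEM cells (Homo sapiens) for inhibition, read by MTT assay, with a stated time of 4 days (a lower number here means a stronger inhibitor, a higher number a weaker inhibitor), each entry a limit and not a number:
- compound 1 `COc1cc(NC(C)CCCNC(=O)NN)c2ncccc2c1`: > 250000 nM
- compound 2 `COc1cc(NC(C)CCCNC(=O)NNC(=O)NCCO)c2ncccc2c1`: > 250000 nM
- compound 3 `COc1cc(NC(C)CCCNC(=O)NNC(=O)N(CCO)CCO)c2ncccc2c1`: > 250000 nM

Compound 3 has no numerical value and stands only at the limit > 250000 nM. The same holds across the series: the limit of > 250000 nM in this assay, at which 3 of the 3 values shown sit.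

The next step leads to compound 4 `COc1cc(NC(C)CCCNC(=O)Nc2ccc(Cl)c(C(F)(F)F)c2)c2ncccc2c1`, with 4-chloro-3-(trifluoromethyl)phenyl in place of (bis(2-hydroxyethyl)carbamoyl)amino on an amide-type nitrogen.

Among the measured compounds shown here, three measured steps bear on this change, all on the same side chain: a step that the two limits leave unreadable from compound 1 to compound 2, a step that the two limits leave unreadable from compound 1 to compound 3 and a step that the two limits leave unreadable from compound 2 to compound 3. For the measured compounds named here, none gives a size to carry over, and none brings in an aromatic ring, so the series offers no direct precedent for this change. The direction of the expectation rests mainly on compound 3, whose limit of > 250000 nM leaves room for a readable move only towards a stronger inhibitor. A clear move in that direction is expected, though with wide uncertainty and some chance that compound 4 also ends at a limit.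

The expected step is an at least 16-fold lower number from compound 3 to compound 4 (1.22 log units; beyond the scatter).

The estimate for compound 4 is 15000 nM, with an expected range from 3000 nM to 80000 nM.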

Compound 4, half-maximal inhibitory concentration: 3100 nM
Beside the measured number, compound 4's estimate is 4.8-fold (0.68 log units) above it; the range from low to high includes it.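

In this assay, among the compounds shown here, the amide-type nitrogen whose other neighbour is the carbonyl carbon is the first place where a change gives a readable result: with 4-chloro-3-(trifluoromethyl)phenyl there, compound 4 gives 3100 nM, and the steps are an at least 80-fold lower number from compound 3 to compound 4 (1.90 log units; beyond the scatter), an at least 80-fold lower number from compound 2 to compound 4 (1.90 log units; beyond the scatter) and an at least 80-fold lower number from compound 1 to compound 4 (1.90 log units; beyond the scatter). All three steps start from a limit, and the steps among compound 1, compound 2 and compound 3 cannot be read, so the hydroxyethyl changes give no size to set against them. Compound 4 is the only one of the series with a number, and it is also the only one here with a six-membered aromatic ring on that nitrogen, while the others stay at one limit: the limit of > 250000 nM in this assay, at which 3 of the 4 values shown sit.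

With one compound carrying the ring, the step cannot be divided among the ring, the chlorine and the trifluoromethyl group. A plain phenyl, a 4-chlorophenyl or a 3-(trifluoromethyl)phenyl on the same nitrogen would separate these parts, and a longer chain in place of the present one would show whether the number of compound 4 depends on the linker.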